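Chloro in Place of Methyl on the Aryl Urea

The compounds below may be only part of what the source reports. "The series", "measured", "known", "first", "only" and "open" are said of these compounds alone.

Three ureas built on the same shared core have been measured in an assay on microsomes from intestine for inhibition of acyl-CoA:cholesterol acyltransferase (Oryctolagus cuniculus); a lower number here means a stronger inhibitor, a higher number a weaker inhibitor. Compound 1 `CC(C)c1cccc(C(C)C)c1NC(=O)NC1CCCc2ccccc21` gives 850 nM, compound 2 `CC(C)c1cccc(C(C)C)c1NC(=O)NCC1(c2ccccc2)CCCCC1` gives 21 nM, and compound 3 `Cc1cccc(NC(=O)NCC2(c3ccccc3)CCCCC2)c1` gives 2800 nM. Compound 3 thus stands highest of the three numbers; its nearest neighbour is compound 1, whose lower number lies beyond the scatter, and its furthest is compound 2, whose much lower number marks it as the strongest inhibitor of the set. Compound 4 `O=C(NCC1(c2ccccc2)CCCCC1)Nc1ccc(Cl)cc1` has not yet been measured in this assay. It differs from compound 3 in one place: 4-chlorophenyl in place of 3-methylphenyl on an amide-type nitrogen. Among the measured compounds shown here, no measured pair shows this exchange, so nothing in the data fixes its direction. Compound 3 and compound 4 both share the same arrangement on the urea that separates them from compound 2, and on that ground the expected step of a 1.1-fold higher number from compound 3 to compound 4 (0.03 log units; within the scatter) is small, not beyond the scatter, with no preferred direction. Compound 4 is therefore estimated to give about 3000 nM, within 1000 nM to 10000 nM.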

Compound 4, half-maximal inhibitory concentration: 2200 nM
The estimate for compound 4 lay 1.4-fold (0.13 log units) above the measured number; the range from low to high includes it.
By their numbers in this assay, from the lowest: compound 2; then compound 1; then compounds 4 and 3 (each within the scatter of the next).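

In this assay, among the compounds shown here, the exchange of 3-methylphenyl for 4-chlorophenyl on the amide-type nitrogen gives a 1.3-fold lower number from compound 3 to compound 4 (0.10 log units; within the scatter) and so provides the first direct reading at this position: the two groups cannot be told apart here, even though they differ in both the atom they carry and its place on the ring. The aryl group of compound 2 remains a different matter, since compound 4 gives 2200 nM and compound 2 gives 21 nM in this assay on the same shared core. Nothing at hand explains why 3-methylphenyl and 4-chlorophenyl read alike. As far as these compounds go, it remains open how an amine, a carboxylic acid or a longer chain in place of the chlorine of 4-chlorophenyl would read. Also open, from the compounds shown here alone, is whether any single group on this ring can approach the number of compound 2.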